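Longer Branched Alcohol on the Triazole of an Oxime Amidine

A few compounds are considered here, and "the series" means these few. Any claim that something is new, unique, unknown or untested is made for them only; others in the source may bear on it.

The three measured compounds share one core and differ only in the alcohol-bearing group on a five-membered aromatic ring with three nitrogens. Compound 1 `OCc1cn(CCNc2nonc2/C(=N/O)Nc2ccc(F)c(Br)c2)nn1` carries a hydroxymethyl group there and, in an assay on isolated protein for inhibition of Indoleamine 2,3-dioxygenase 2 (Homo sapiens) (on this read-out lower numbers stand for stronger inhibition and higher numbers for weaker inhibition), compound 1 gives 794 nM. Compound 2 `OCCc1cn(CCNc2nonc2/C(=N/O)Nc2ccc(F)c(Br)c2)nn1` carries a 2-hydroxyethyl group, and in this assay compound 2 gives 1170 nM. Compound 3 `CCC(C)(O)c1cn(CCNc2nonc2/C(=N/O)Nc2ccc(F)c(Br)c2)nn1` carries a 1-hydroxy-1-methylpropyl group, and in this assay compound 3 gives 958 nM. Compound 2 sits among these values without standing apart: the steps of a 1.5-fold higher number from compound 1 to compound 2 (0.17 log units; within the scatter) and a 1.2-fold lower number from compound 2 to compound 3 (0.09 log units; within the scatter) both lie within the scatter, as does a 1.2-fold higher number from compound 1 to compound 3 (0.08 log units; within the scatter), so the three cannot be told apart.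

Compound 4 `CC(C)CC(C)(O)c1cn(CCNc2nonc2/C(=N/O)Nc2ccc(F)c(Br)c2)nn1` is not yet measured. Its change from compound 2 is 1-hydroxy-1,3-dimethylbutyl in place of 2-hydroxyethyl on an aromatic carbon. The closest guide is the step from compound 2 to compound 3, where a 2-hydroxyethyl group was likewise replaced by a branched tertiary alcohol and the number moved only a 1.2-fold lower number from compound 2 to compound 3 (0.09 log units; within the scatter). Growing that alcohol further, as in compound 4, is therefore expected to give no step beyond the scatter, a 1.2-fold lower number from compound 2 to compound 4 (0.07 log units; within the scatter). Compound 4 is estimated at 1000 nM, within a range from 400 nM to 2500 nM.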

Compound 4, half-maximal inhibitory concentration: 689 nM
Estimate against measurement, compound 4: 1.5-fold (0.16 log units) above; the measured number falls inside the stated range.
By their numbers in this assay, from the lowest: compounds 4, 1, 3 and 2 (each within the scatter of the next).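

Compound 4 carries a 1-hydroxy-1,3-dimethylbutyl group of 7 heavy atoms where compound 2 has a 2-hydroxyethyl group of 3, yet in this assay this larger change still gives only a step within the scatter (a 1.7-fold lower number from compound 2 to compound 4 (0.23 log units; within the scatter)). Changing the end of the chain also leaves the read-out within the scatter: isopropyl in place of methyl gives a 1.4-fold lower number from compound 3 to compound 4 (0.14 log units; within the scatter) and the comparison with the smallest alcohol gives a 1.2-fold lower number from compound 1 to compound 4 (0.06 log units; within the scatter). So, across these four compounds, an aromatic carbon of the five-membered ring with 3 nitrogen accepts a much larger branched alcohol without a step that can be told apart from the scatter. No measurement here explains why the number responds so little to this growth.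

All four groups keep a hydroxy group, so the compounds leave open what an amine, a carboxylic acid or a plain alkyl chain without oxygen would give at this position. They also leave open how far the group can grow, since a longer chain or a phenyl ring could still produce a step beyond the scatter.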